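The compounds below may be only part of what the source reports. "The series", "measured", "known", "first", "only" and "open" are said of these compounds alone.

Compound 3 `CCOC(=O)c1c(-c2cc3ccc(OCC=C(C)C)cc3oc2=O)nn(-c2ccccc2)c1C(=O)OCC` was measured in a functional assay on HeLa cells (Homo sapiens) for cytotoxicity, read by MTT assay, with a stated time of 48 h (a higher number here means a weaker inhibitor, a lower number a stronger inhibitor), where compound 3 gives 130000 nM. Among the three compounds with numbers, compound 3 stands second highest. Its nearest neighbour is compound 1 `CCOC(=O)c1c(-c2cc3ccccc3oc2=O)nn(-c2cccc(C)c2)c1C(=O)OCC`, which in this assay gives 245000 nM, a number within the scatter of compound 3; furthest from it is compound 2 `CCOC(=O)c1c(-c2cc3ccc(OC)cc3oc2=O)nn(-c2cccc(C)c2)c1C(=O)OCC`, which gives 35000 nM, a lower number beyond the scatter. Going by the values given here, the one single-change step that has been measured, a 7.0-fold lower number from compound 1 to compound 2 (0.85 log units; beyond the scatter), concerns a different group at a different place, and so it does not bear on the change considered here.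

Compound 4 `CCOC(=O)c1c(-c2cc3ccc(OCC=C(C)C)cc3oc2=O)nn(-c2cccc(C)c2)c1C(=O)OCC` differs from compound 3 by methyl in place of hydrogen on an aromatic carbon. Among the compounds with values here, no measured step covers this change on its own. Compound 1 and compound 3 differ in the same way, but they also differ at a second place, so their two values show only that they lie within the scatter of each other. With nothing pointing either way, the expectation for compound 4 is a step of about no change at the digits printed from compound 3 to compound 4 (within the scatter), that is, no change beyond the scatter. Compound 4 is therefore estimated at 130000 nM in this assay, with a range from 50000 nM to 340000 nM.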

Compound 4, half-maximal inhibitory concentration: 150000 nM
Beside the measured number, compound 4's estimate is 1.2-fold (0.06 log units) below it, within the range that was stated.
By their numbers in this assay, from the lowest: compound 2; then compounds 3, 4 and 1 (each within the scatter of the next).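

With the (3-methylbut-2-en-1-yl)oxy group held in place, the change from phenyl to 3-methylphenyl can now be read on its own in this assay: a 1.2-fold higher number from compound 3 to compound 4 (0.06 log units; within the scatter), so this methyl in place of hydrogen on an aromatic carbon leaves the number within the scatter. Compound 4 also allows the ether group to be compared with the 3-methylphenyl group held fixed: a 1.6-fold lower number from compound 1 to compound 4 (0.21 log units; within the scatter) stays within the scatter, whereas a 4.3-fold higher number from compound 2 to compound 4 (0.63 log units; beyond the scatter) lies beyond it, so that compound 2, with its methoxy group, stands apart from both compound 1 and compound 4 in this set. No measurement is available that would account for any of these steps.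

Going by these compounds, what remains open is whether another group at this place on the phenyl ring, such as a chlorine, a methoxy or an amine, would move the number beyond the scatter. Also open, on these data alone, is whether the methyl step would stay within the scatter with the methoxy group of compound 2 in place of the (3-methylbut-2-en-1-yl)oxy group.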